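This account rests on a few compounds, and the source may have more. Where it says the series, first, only, none or still open, it means among the compounds named here.

Measured so far:
Compound 1 `COc1cccc(S(=O)(=O)Nc2cccc(-c3nc(-c4ccc(NC(=O)c5cccnc5)cc4Cl)no3)c2)c1` — in a functional assay on MDA-MB-231 cells (Homo sapiens) for antiproliferative activity, read by MTT assay, with a stated time of 72 h (on this read-out lower numbers stand for stronger inhibition and higher numbers for weaker inhibition), compound 1 gives a limit of the assay, > 10000 nM.
Compound 2 `CC(=O)Nc1ccc(S(=O)(=O)Nc2cccc(-c3nc(-c4ccc(NC(=O)c5cccnc5)cc4Cl)no3)c2)cc1` — in this assay compound 2 gives 2500 nM.

Going by the values given here, compound 2 holds the only numerical value; the other entry is a limit, (the limit of > 10000 nM in this assay, at which 1 of the 2 values shown sits). Among the compounds with values here, the one step measured, an at least 4.0-fold lower number from compound 1 to compound 2 (0.60 log units; beyond the scatter), concerns the aryl on the sulfonyl sulfur, not the site changed here.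

Compound 3 `O=C(Nc1ccc(-c2noc(-c3cccc(NS(=O)(=O)c4ccc(NC(=O)N5CCCC5)cc4)c3)n2)c(Cl)c1)c1cccnc1` differs from compound 2 by pyrrolidin-1-yl in place of methyl on a carbonyl carbon. Within the data shown here, no measured step touches the carbonyl carbon, so the step from compound 1 to compound 2 bears on this change only as a reminder that the series can move with remote substitution. With nothing closer to lean on, the step of a 1.1-fold lower number from compound 2 to compound 3 (0.06 log units; within the scatter) is expected to stay within the scatter. Compound 3 is therefore estimated at 2200 nM in this assay, with a range from 600 nM to 8000 nM.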

Compound 3, half-maximal inhibitory concentration: 5800 nM
Compound 3: middle estimate off by 2.6-fold (0.42 log units), on the low side; low and high end bracket the measured number.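

The carbonyl carbon is not a silent site in this assay: exchanging acetamido for ((pyrrolidin-1-yl)carbonyl)amino gives a 2.3-fold higher number from compound 2 to compound 3 (0.37 log units; beyond the scatter). The step is modest, and it comes with an entering group that adds a five-membered non-aromatic ring and a nitrogen while the counted hydrogen-bond donors and acceptors of the leaving and entering groups stay equal. Compound 1 remains a limit and not a number: the limit of > 10000 nM in this assay, at which 1 of the 3 values shown sits.

A single step at this carbonyl carbon cannot separate the contribution of the ring from that of its nitrogen or of the added carbons. Dimethylamino or cyclopentyl in place of pyrrolidin-1-yl would address that question, and whether any group here gives a lower number than methyl stays open.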